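The source may hold more compounds than are shown below. What is called first, only, known or untested is meant among the compounds shown, and "the series" means these compounds.

Measured compounds:
- Compound 1, `Nc1nc(-c2ccccc2)cn1/N=C/c1cc2ccccc2nc1Cl`, gives 46700 nM in an ADME assay on HUVEC cells (Homo sapiens) for cytotoxicity, read by MTT assay, with a stated time of 48 h; on this read-out lower numbers stand for stronger inhibition and higher numbers for weaker inhibition.
- Compound 2, `Nc1nc(-c2ccc(Br)cc2)cn1/N=C/c1cc2ccccc2nc1Cl`, gives 11900 nM in this assay.
- Compound 3, `Cc1ccc2nc(Cl)c(/C=N/n3cc(-c4ccccc4)nc3N)cc2c1`, gives 41500 nM in this assay.

Compound 3 stands second highest of the three numbers; its value sits within the scatter of compound 1, and the two are not told apart, while compound 2 lies a 3.9-fold lower number from compound 1 to compound 2 (0.59 log units; beyond the scatter) below compound 1 and therefore also clearly below compound 3.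

Compound 4, `Cc1ccc2nc(Cl)c(/C=N/n3cc(-c4ccc(Cl)cc4)nc3N)cc2c1`, is not yet measured. It differs from compound 3 by chloro in place of hydrogen on an aromatic carbon. Going by the values given here, the one measured step that bears on this is the step from compound 1 to compound 2, where bromo took the place of hydrogen on the same aromatic carbon and gave a 3.9-fold lower number from compound 1 to compound 2 (0.59 log units; beyond the scatter). The step from compound 1 to compound 3 does not touch this position. A chloro group at the same place is expected to behave similarly, so a step of about a 3.0-fold lower number from compound 3 to compound 4 (0.47 log units; beyond the scatter) is expected. Compound 4 is therefore estimated at 14000 nM, with a range from 6000 nM to 35000 nM.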

Compound 4, half-maximal inhibitory concentration: 38500 nM
Compound 4: middle estimate off by 2.8-fold (0.44 log units), on the low side; measured number outside the range, above it.
By their numbers in this assay, from the lowest: compound 2; then compounds 4, 3 and 1 (each within the scatter of the next).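

In this assay, chloro in place of hydrogen, which turns phenyl into 4-chlorophenyl, gives a 1.1-fold lower number from compound 3 to compound 4 (0.03 log units; within the scatter) and so leaves the two compounds not told apart. The earlier change at this place gave a 3.9-fold lower number from compound 1 to compound 2 (0.59 log units; beyond the scatter) with bromo as the entering group and no methyl on the core, so a halogen here does not always go with a lower number. Two things differ between these steps, the halogen and the methyl, and no measurement shown explains the contrast.

The compounds shown leave open how chloro behaves on the core of compound 1 and how bromo behaves on the core of compound 3, either of which would help separate the halogen from the methyl. They also leave open what a methoxy group or an amine would do at this same place.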